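The source may report more compounds than this note shows. Statements on the series, on what has been measured and on what is new or still open speak of the compounds shown alone.

Compound 1 `Cc1ccc(/C=C/C(=O)O/C(=N/C2CCCCC2)NC2CCCCC2)cc1` gives 95.5% in an ADME assay on Vero cells (Chlorocebus sabaeus) for cytotoxicity, read by WST assay, tested at 100 ug/mL; on this read-out lower numbers stand for a stronger effect and higher numbers for a weaker effect at the one concentration tested. Compound 2 `O=C(/C=C/c1ccccc1)O/C(=N/C1CCCCC1)NC1CCCCC1` gives 83.8% in this assay. Compound 3 `COC(=O)c1coc(/C=C/c2ccc(C)cc2)n1` gives 100% in this assay.

Compound 1 and compound 2 share one core and differ only by hydrogen in place of methyl on an aromatic carbon. In this assay that change made a number 11.7 percentage points lower from compound 1 to compound 2 (beyond the scatter), so the compound without the methyl acted a little more strongly on the cells. Compound 3 rests on another core; how the two cores differ is not broken down here. Compound 4 `COC(=O)c1coc(/C=C/c2ccccc2)n1` is not yet measured. It differs from compound 3 by hydrogen in place of methyl on an aromatic carbon, the same change at the same kind of place as before. The expected step in this assay is a number 10 percentage points lower from compound 3 to compound 4 (within the scatter), a modest drop of similar size, because the same change made a number 11.7 percentage points lower from compound 1 to compound 2 (beyond the scatter). Compound 4 is thus estimated at 90%, expected between 76% and 100%.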

Compound 4, a percentage reported as activity, at one concentration (the size of the read-out at that concentration, not a potency): 102%
Compound 4: middle estimate off by 12 percentage points, on the low side, and the stated range ends below it.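

Replacing methyl with hydrogen on the core of compound 3 gave a number 2 percentage points higher from compound 3 to compound 4 (within the scatter) in this assay, so no effect of the change can be seen on this core. Set beside the earlier step, the two steps cannot be told apart: the same change on two cores in this assay, a number 11.7 percentage points lower (beyond the scatter) from compound 1 to compound 2 and a number 2 percentage points higher (within the scatter) from compound 3 to compound 4, 13.7 percentage points apart, within the scatter of two such steps. This does not show that the change acts alike on both cores, nor that it acts differently, as two pairs, one with a step inside the scatter, cannot settle either point.

Only methyl and hydrogen appear at this place on the ring, leaving open what a chlorine atom, a methoxy group or an amine would do there. Also open, going by these compounds, is how the same change behaves on any third core.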